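Working notes: amine substituent, compound 3 to compound 4

The source may hold more compounds than are shown below. What is called first, only, known or untested is meant among the compounds shown, and "the series" means these compounds.

Measured so far in an ADME assay on S9 fraction from liver (Homo sapiens) for metabolic stability, with a stated time of 1 h; on this read-out lower numbers stand for a less stable compound and higher numbers for a more stable compound:
- compound 1 `N#Cc1cnc(NCc2cnccc2C(F)(F)F)cc1N[C@H]1C[C@H](O)C1`: 96%
- compound 2 `N#Cc1cnc(NCc2ccccc2C(F)(F)F)cc1N[C@H]1CC[C@@H](O)CC1`: 0%
- compound 3 `N#Cc1cnc(NCc2cnccc2C(F)(F)F)cc1N[C@H]1CC[C@H](O)CC1`: 30%

Compound 3, at 30%, stands second of the three. It lies under compound 1 and over compound 2, both gaps being beyond the scatter.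

The next structure is compound 4 `CO[C@H]1CC[C@@H](CNc2cc(NCc3cnccc3C(F)(F)F)ncc2C#N)CC1`. The change is (4-methoxycyclohexyl)methyl in place of 4-hydroxycyclohexyl on a nitrogen on an aromatic ring.

Among the measured compounds shown here, one measured step bears on this place: a number 66 percentage points lower from compound 1 to compound 3 (beyond the scatter). That step was large, and it exchanged 3-hydroxycyclobutyl for 4-hydroxycyclohexyl. For the measured compounds named here, it is only a partial guide, since no measured compound carries the methoxy group or the (4-methoxycyclohexyl)methyl group. The entering group is again the one with more heavy atoms, so the direction of that step is expected to hold, though with a smaller size. The room for a fall is also limited, with compound 3 starting from 30%. The expected change is a modest fall, estimated as a number 15 percentage points lower from compound 3 to compound 4 (beyond the scatter) in this assay.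

For compound 4 the estimated value is 15%, with an expected range from 0% to 40%.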

Compound 4, percent of the compound remaining: 4%
Compound 4: middle estimate off by 11 percentage points, on the high side; the measured number falls inside the stated range.
By their numbers in this assay, from the lowest: compounds 2 and 4 (each within the scatter of the next); then compound 3; then compound 1.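

Replacing 4-hydroxycyclohexyl with (4-methoxycyclohexyl)methyl on the nitrogen on the aromatic ring gives a number 26 percentage points lower from compound 3 to compound 4 (beyond the scatter) in this assay, so this position still affects stability when the starting number is already low. Taken with a number 66 percentage points lower from compound 1 to compound 3 (beyond the scatter) and a number 92 percentage points lower from compound 1 to compound 4 (beyond the scatter), it gives a falling order across compounds 1, 3 and 4, which share the rest of the structure, and none of these three goes against it: 3-hydroxycyclobutyl is highest, 4-hydroxycyclohexyl next and (4-methoxycyclohexyl)methyl lowest. This step also shows that a compound with no hydrogen-bond donor in this group and one more carbon-based link can sit lower than compound 3, although no supporting data explain the fall.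

The step changes two things at once, so the compounds shown do not separate the methoxy group from the added methylene link; (4-hydroxycyclohexyl)methyl and 4-methoxycyclohexyl on the same nitrogen would pull these apart. From the compounds shown here alone, it also remains open whether 3-methoxycyclobutyl would keep the high number of compound 1 at 96%, or whether the small ring holds up only with the free hydroxyl.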